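This account rests on a few compounds, and the source may have more. Where it says the series, first, only, none or still open, it means among the compounds named here.

Series notes. Three analogues sharing one core have been run in a functional assay on MDA-MB-231 cells (Homo sapiens) for antiproliferative activity, read by MTT assay, with a stated time of 24 h; a higher number here means a weaker inhibitor, a lower number a stronger inhibitor. Compound 1 `COc1ccc(-c2cc(/C=C/C(=O)c3ccc(C)cc3)nc3cc(-c4ccccc4)nn23)cc1OC` gives 19800 nM. Compound 2 `COc1cc(-c2cc(/C=C/C(=O)c3ccc(C)cc3)nc3cc(-c4ccccc4)nn23)cc(OC)c1OC` gives 23900 nM. Compound 3 `COc1ccc(C(=O)/C=C/c2cc(-c3ccc(OC)c(OC)c3)n3nc(-c4ccccc4)cc3n2)cc1` gives 13900 nM. The change from compound 2 to compound 1 is hydrogen in place of methoxy on an aromatic carbon and produced a 1.2-fold lower number from compound 2 to compound 1 (0.08 log units; within the scatter). Between compound 1 and compound 3 the step is a 1.4-fold lower number from compound 1 to compound 3 (0.15 log units; within the scatter). The difference between the cores of compound 3 and compound 2 is not broken down here. All three values sit within the scatter of one another, so no ordering among them is claimed.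

Compound 4 `COc1ccc(C(=O)/C=C/c2cc(-c3ccc(OC)cc3)n3nc(-c4ccccc4)cc3n2)cc1` has not yet been measured. Its difference from compound 3 is hydrogen in place of methoxy on an aromatic carbon. This is the same kind of change as that from compound 2 to compound 1, though the surroundings differ: in the earlier pair the site is also meta to a methoxy group, which is absent here. The step expected for compound 4, a 1.2-fold lower number from compound 3 to compound 4 (0.06 log units; within the scatter), is small because a 1.2-fold lower number from compound 2 to compound 1 (0.08 log units; within the scatter) stayed within the scatter. Compound 4 is estimated at 12000 nM in this assay, with a range from 6000 nM to 25000 nM.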

Compound 4, half-maximal inhibitory concentration: 6300 nM
Compound 4: the middle estimate sits 1.9-fold (0.28 log units) above what was measured; the range from low to high includes it.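

In this assay, the change from 3,4-dimethoxyphenyl to 4-methoxyphenyl gives a 2.2-fold lower number from compound 3 to compound 4 (0.34 log units; beyond the scatter), a modest step. Set beside the earlier case of hydrogen in place of methoxy, the new step cannot be called different, and the core cannot be said to alter the effect of this change: the same change on two cores in this assay, a 1.2-fold lower number (0.08 log units; within the scatter) from compound 2 to compound 1 and a 2.2-fold lower number (0.34 log units; beyond the scatter) from compound 3 to compound 4, 1.8-fold (0.26 log units) apart, within the scatter of two such steps. Both steps point towards a lower number, but only the newer one lies beyond the scatter, and two pairs show neither that the change carries over at a fixed size nor that it would do so on any further core.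

On these data alone, it remains open whether the trend continues when the last methoxy on that ring is replaced by hydrogen, leaving an unsubstituted phenyl. Also open, as far as these compounds go, is how a hydroxyl, an amine or a fluorine at the same place on the ring would compare with methoxy in this assay.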